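The source may hold more compounds than are shown below. What is called first, only, known or untested is meant among the compounds shown, and "the series" means these compounds.

Of the compounds shown here, three of one shared core have been measured for solubility. Compound 1 `Cc1nc(-c2nc(C(F)(F)F)no2)c(N)c2c1C(=O)N(Cc1ccccc1)C2=O` gives only a limit of the assay in a physicochemical assay for solubility, using the shake flask method, in simulated intestinal fluid, measured as kinetic solubility, with a stated time of 2 h, at 25 degrees C, at pH 6.5 (a lower number here means a less soluble compound, a higher number a more soluble compound), at < 5000 nM. Compound 3 `COc1cccc(CN2C(=O)c3c(C)nc(-c4nc(C)no4)c(N)c3C2=O)c1` likewise reaches only a limit in this assay, at < 5000 nM. Among the compounds with values here, compound 2 `Cc1noc(-c2nc(C)c3c(c2N)C(=O)N(Cc2ccc(Oc4ccc(F)cc4)cc2)C3=O)n1` is the one compound with a real number in this assay, at 23800 nM, so it stands alone as the reference point; the other two values sit at the limit of < 5000 nM in this assay, at which 2 of the 3 values shown sit.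

The step under consideration leads from compound 2 to compound 4 `Cc1noc(-c2nc(C)c3c(c2N)C(=O)N(Cc2ccc(N4CCCC4=O)cc2)C3=O)n1`. The change is confined to one spot on the benzyl part of the molecule (2-oxopyrrolidin-1-yl in place of 4-fluorophenoxy on an aromatic carbon). A 2-oxopyrrolidin-1-yl group thus takes the place of the 4-fluorophenoxy group.

Within the data shown here, with no measured step between paired compounds available, the size of the change can only be guessed from the single number of compound 2. The step from compound 2 to compound 4 is expected to raise solubility beyond the usual scatter, by about a 2.5-fold higher number from compound 2 to compound 4 (0.40 log units; beyond the scatter). Compound 4 is therefore estimated at 60000 nM, with a likely range from 18000 nM to 200000 nM.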

Compound 4, solubility: < 5000 nM
Compound 4: no number, only a limit; the forecaster's own chance of this, stated with the estimate: 10%; at least 12-fold (1.07 log units) between middle value and limit.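

In this assay, compound 4 gives < 5000 nM, which is a limit of the assay and not a real number. Within the data shown here, this is the first reading of a change at this place, on an aromatic carbon para to a large group: putting 2-oxopyrrolidin-1-yl in place of 4-fluorophenoxy gives an at least 4.7-fold lower number from compound 2 to compound 4 (0.67 log units; beyond the scatter). Compound 2 therefore remains the only compound with a real number, and compound 4 joins the others at the limit: the limit of < 5000 nM in this assay, at which 3 of the 4 values shown sit.

From the compounds shown here alone, the true size of this step stays open, since the result for compound 4 gives only a limit. It is also unknown whether a morpholine ring, a primary amine or a carboxylic acid at the same place would hold the value of compound 2 or also fall to the limit.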